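The source may hold more compounds than are shown below. What is called first, only, known or untested is meant among the compounds shown, and "the series" means these compounds.

In a functional assay on KB cells (Homo sapiens) for antiproliferative activity, read by sulforhodamine B assay, with a stated time of 3 days (a lower number here means that less compound is needed, a higher number that more compound is needed for the effect), compound 2 (`CCC1=C(O)c2c(oc(-c3ccc(CBr)cc3)cc2=O)C(CC)(CC)C1=O`) gives > 46.5 uM, which is a limit and not a number. Compound 1 (`CCOc1ccc(-c2cc(=O)c3c(o2)C(CC)(CC)C(=O)C(CC)=C3O)cc1`) also gives only a limit, > 52.4 uM. Compound 3 (`CCC1=C(O)c2c(oc(-c3cccc(OC)c3)cc2=O)C(CC)(CC)C1=O`) has 3-methoxyphenyl in place of 4-(bromomethyl)phenyl on an aromatic carbon. For the measured compounds named here, the only measured step that bears on this change is a step that the two limits leave unreadable from compound 1 to compound 2, and it offers no size to carry over. No clear move is therefore expected in this assay, and the expected step is a step that the limit leaves unreadable from compound 2 to compound 3. For compound 3 the estimated value is 50 uM, with an expected range from 20 uM to 80 uM.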

Compound 3, concentration for half-maximal effect: 13.3 uM
Compound 3: the middle estimate sits 3.8-fold (0.58 log units) above what was measured, and the stated range ends above it.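

In this assay, for the compounds shown here, compound 3 gives 13.3 uM, the first number in this set rather than a limit. On the aromatic carbon next to the ring oxygen, 3-methoxyphenyl gives an at least 3.4-fold lower number from compound 2 to compound 3 (0.54 log units; beyond the scatter), and it also gives an at least 3.9-fold lower number from compound 1 to compound 3 (0.59 log units; beyond the scatter). The step between the two earlier compounds cannot be read, so this position first shows a response to a change of aryl group here. The compounds shown leave open whether the lower number goes with the methoxy group itself or with where it sits on the phenyl ring. They include neither 4-methoxyphenyl nor 3-aminophenyl at this place.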